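The source may hold more compounds than are shown below. What is called first, only, known or untested is meant among the compounds shown, and "the series" means these compounds.

Compound 1 `CCOc1cc(NC(=O)C2(NC(=O)c3ccc4c(C5CCCC5)c(-c5ncc(Cl)cn5)n(C)c4c3)CCC2)ccc1/C=C/C(=O)OCC(C)C`: in an ADME assay (liver) for pharmacokinetics, with Liver microsome (Homo sapiens) as the target, using microsomes (on this read-out lower numbers stand for a shorter-lived compound and higher numbers for a longer-lived compound), compound 1 gives > 5 h, which is a limit of the assay.
Compound 2 `CCOc1cc(NC(=O)C2(NC(=O)c3ccc4c(C5CCCC5)c(-c5ncc(Cl)cn5)n(C)c4c3)CCC2)ccc1/C=C/C(=O)OCC(=O)OCc1ccc(Cl)cc1`: in this assay compound 2 gives 5.62 h.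

Compound 2 holds the only number shown; the remaining value is the limit of compound 1 (the limit of > 5 h in this assay, at which 1 of the 2 values shown sits), so the step that the limit leaves unreadable from compound 1 to compound 2 cannot be read. Compound 3 `CCOc1cc(NC(=O)C2(NC(=O)c3ccc4c(C5CCCC5)c(-c5ncc(Cl)cn5)n(C)c4c3)CCC2)ccc1/C=C/C(=O)OCC(=O)N1CCOCC1` differs from compound 2 by morpholin-4-yl in place of (4-chlorobenzyl)oxy on a carbonyl carbon. No readable measured step bears on this change, so no shift beyond the scatter is expected, and the step from compound 2 to compound 3 is estimated at a 1.1-fold lower number from compound 2 to compound 3 (0.05 log units; within the scatter). Compound 3 is expected at 5 h, between 2.5 h and 10 h.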

Compound 3, half-life: 0.667 h
Estimate against measurement, compound 3: 7.5-fold (0.87 log units) above; measured number below the stated range.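

In this assay, within the data shown here, the group on this carbonyl carbon matters: morpholin-4-yl in place of (4-chlorobenzyl)oxy gives an 8.4-fold lower number from compound 2 to compound 3 (0.93 log units; beyond the scatter), the first readable step between two measured numbers. Against the isopropyl ester, (morpholin-4-yl)carbonyl gives an at least 7.4-fold lower number from compound 1 to compound 3 (0.87 log units; beyond the scatter). Compound 1 stands at a limit, so its step to compound 2 cannot be read and its step to compound 3 is only a bound: the limit of > 5 h in this assay, at which 1 of the 3 values shown sits.

Going by these compounds, whether the drop follows the morpholin-4-yl ring itself or any amide at this carbonyl carbon stays open. A piperidin-1-yl or dimethylamino group there would separate the two.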